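The source may report more compounds than this note shows. Statements on the series, on what has been measured and on what is new or still open speak of the compounds shown alone.

In a functional assay on NCI-H460 cells (Homo sapiens) for inhibition, read by sulforhodamine B assay, with a stated time of 48 h (a lower number here means a stronger inhibitor of growth, a higher number a weaker inhibitor of growth), compound 3 (`CC(C)(C)NCc1c(C(=O)O)nn(-c2ccccc2)c1-c1ccccc1`) gives > 716000 nM, which is a limit of the assay and not a number. Compound 2 (`CC(C)(C)NCc1c(C(=O)O)nn(-c2ccccc2)c1-c1ccc(Cl)cc1`) gives 70500 nM in this assay. Within the data shown here, the one measured step that bears directly on this position is an at least 10-fold higher number from compound 2 to compound 3 (1.00 log units; beyond the scatter), which puts hydrogen in place of chloro on an aromatic carbon and lies beyond the scatter.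

Compound 4 (`Cc1ccc(-c2c(CNC(C)(C)C)c(C(=O)O)nn2-c2ccccc2)cc1`) differs from compound 3 by methyl in place of hydrogen on an aromatic carbon, turning phenyl into 4-methylphenyl. Compound 1 (`CCOC(=O)c1nn(-c2ccccc2)c(-c2ccc(C)cc2)c1CNC(C)(C)C`) also carries 4-methylphenyl, and its entries of 75300 nM; > 585000 nM (2 entries) give only loose guidance.

Read backwards, the step to compound 3 suggests that a group in place of that hydrogen may lower the number, although methyl is not chloro and this is a single pair. The expected change is an at least 3.5-fold lower number from compound 3 to compound 4 (0.55 log units; beyond the scatter), toward stronger inhibition of growth. A limit could well be reported again. For compound 4 the estimate is 200000 nM, with an expected range from 60000 nM to 700000 nM.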

Compound 4, concentration for 50% growth inhibition: > 688000 nM
Compound 4 ended at the assay's limit; the forecaster's own chance of this, stated with the estimate: 45%; at least 3.4-fold (0.53 log units) between middle value and limit.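

In this assay the new pair shows that methyl does not stand in for chloro on this aromatic carbon: the swap gives an at least 9.7-fold higher number from compound 2 to compound 4 (0.98 log units; beyond the scatter) and takes the compound out of the range of measured numbers. Compound 4 gives > 688000 nM and that is a limit of the assay and not a number. Compound 3 also sits at a limit, so the step between compound 3 and compound 4 cannot be read, and among these three compounds with the free carboxylic acid only compound 2, with its chloro group, gives a real number.

Going by these compounds, whether methyl changes anything at all compared with hydrogen stays open. On these data alone, it is also open whether a bromo, a methoxy or an amine group in this place would behave like chloro or like methyl.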